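The source may report more compounds than this note shows. Statements on the series, on what has been measured and on what is new or still open speak of the compounds shown alone.

In a functional assay on the whole organism with Mus musculus as the target (on this read-out lower numbers stand for an effect already at smaller amounts and higher numbers for an effect only at larger amounts of compound), compound 1 `Cc1c(C)c2c(c(C)c1N)CC(C)(C)O2` gives 7.8 mg/kg. Compound 2 `Cc1c(C)c2c(c(C)c1N)CC(C)(CSc1ccccc1)O2` carries a phenylsulfanyl group on a saturated chain carbon bound to a saturated ring carbon, and it gives 24.7 mg/kg. Compound 3 `Cc1c(C)c2c(c(C)c1N)CC(C)(CSCCO)O2` has (2-hydroxyethyl)sulfanyl at that place and gives > 50 mg/kg, which is a limit of the assay and not a number. Compound 3 therefore stands at the limit of > 50 mg/kg in this assay, at which 1 of the 3 values shown sits.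

Compound 4 `Cc1c(C)c2c(c(C)c1N)CC(C)(CN1CCN(C)CC1)O2` has 4-methylpiperazin-1-yl in place of the (2-hydroxyethyl)sulfanyl of compound 3, on the same carbon (4-methylpiperazin-1-yl in place of (2-hydroxyethyl)sulfanyl on a saturated chain carbon bound to a saturated ring carbon). Within the data shown here, three measured steps bear on this exchange. Putting a side chain on compound 1 gave a 3.2-fold higher number from compound 1 to compound 2 (0.50 log units; beyond the scatter) in one case and an at least 6.4-fold higher number from compound 1 to compound 3 (0.80 log units; beyond the scatter) in the other, while the exchange on sulfur gave an at least 2.0-fold higher number from compound 2 to compound 3 (0.30 log units; that floor lies within the scatter). Both measured side chains thus moved the number up from compound 1, but neither contains a piperazine ring, so they offer only a rough guide. The limit also leaves the size of any step open. A modest move towards a lower number is expected, and the estimate for this exchange is an at least 1.6-fold lower number from compound 3 to compound 4 (0.22 log units; that floor lies within the scatter). For compound 4 the expected dose is 30 mg/kg, with an estimated range from 10 mg/kg to 100 mg/kg.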

Compound 4, dose for 50% inhibition: 25.3 mg/kg
Compound 4: middle estimate off by 1.2-fold (0.07 log units), on the high side; the range from low to high includes it.
By their numbers in this assay, from the lowest: compound 1; then compounds 2 and 4 (each within the scatter of the next). At a limit, above all of these: compound 3.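

Replacing hydrogen with 4-methylpiperazin-1-yl on a saturated chain carbon bound to a saturated ring carbon gives a 3.2-fold higher number from compound 1 to compound 4 (0.51 log units; beyond the scatter), so all three side chains shown now move the number the same way, and a sulfur atom on this carbon is not needed for that. Exchanging phenylsulfanyl for 4-methylpiperazin-1-yl gives a 1.0-fold higher number from compound 2 to compound 4 (0.01 log units; within the scatter), so these two different groups cannot be told apart on this read-out, while exchanging (2-hydroxyethyl)sulfanyl for it gives an at least 1.9-fold lower number from compound 3 to compound 4 (0.29 log units; that floor lies within the scatter), a floor that also lies within the scatter. That last step can be read only as a floor because the value of compound 3 is a limit of the assay and not a number: the limit of > 50 mg/kg in this assay, at which 1 of the 4 values shown sits.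

Going by these compounds, what remains open is how far compound 3 really lies from the other compounds, and whether any side chain at this place can match the number of compound 1 or go lower. A small open-chain amine such as dimethylamino, a carboxylic acid or a longer carbon chain on the same carbon would show whether the rise holds beyond the three side chains shown here.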